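This account rests on a few compounds, and the source may have more. Where it says the series, first, only, none or still open, it means among the compounds named here.

Measured compounds:
compound 1, `CCCOc1c(NC(=O)N(O)C(C)CC)cc(C2CCC(c3cc(OC)c(OC)c(OC)c3)O2)cc1OC`, 600 nM; 450 nM (2 entries)
compound 2, `CCCOc1c(NC(=O)N(O)C(C)(C)C)cc(C2CCC(c3cc(OC)c(OC)c(OC)c3)O2)cc1OC`, 2900 nM
compound 3, `CCCOc1c(NC(=O)N(O)CCC)cc(C2CCC(c3cc(OC)c(OC)c(OC)c3)O2)cc1OC`, 10000 nM; 10000 nM (2 entries)

Of the compounds shown here, three sharing one core have been tested in a functional assay on RBL-2H3 cells for inhibition of Polyunsaturated fatty acid 5-lipoxygenase (Rattus norvegicus); a higher number here means a weaker inhibitor, a lower number a stronger inhibitor. Compound 1 carries a butan-2-yl group on the hydroxylated nitrogen and gives 600 nM; 450 nM (2 entries); its repeat entries, (the several entries of compound 1 in this assay, 600 nM; 450 nM (2 entries)), show how closely two runs agree. Compound 2, with a tert-butyl group in that place, gives 2900 nM, a single entry, and stands between compound 1 and compound 3 on the numbers shown. Compound 3, bearing a propyl group, gives 10000 nM; 10000 nM (2 entries).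

Compound 4, `CCCOc1c(NC(=O)N(O)C2CCCCC2)cc(C2CCC(c3cc(OC)c(OC)c(OC)c3)O2)cc1OC`, has not yet been tested. It differs from compound 2 by one change: cyclohexyl in place of tert-butyl on an amide-type nitrogen. For the measured compounds named here, no measured pair shows this exact change, so the expectation rests on the three values above. Since the branched secondary group of compound 1 gives the lowest value and the straight chain of compound 3 the highest, a secondary cyclic group is expected to sit near compound 2 or somewhat lower, so that from compound 2 to compound 4 a modest step is expected, a 2.4-fold lower number from compound 2 to compound 4 (0.38 log units; beyond the scatter), of a size that may not exceed the scatter. Compound 4 is therefore expected to give about 1200 nM, within 300 nM to 5000 nM.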

Compound 4, half-maximal inhibitory concentration: 2540 nM
The estimate for compound 4 lay 2.1-fold (0.33 log units) below the measured number; low and high end bracket the measured number.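

In this assay, cyclohexyl in place of tert-butyl on the amide-type nitrogen gives a 1.1-fold lower number from compound 2 to compound 4 (0.06 log units; within the scatter), so this change does not separate the two groups, although cyclohexyl brings a six-membered ring to this place for the first time among the compounds shown. The earlier compounds shown here showed this position responding strongly, with compound 1 at 600 nM; 450 nM (2 entries) and compound 3 at 10000 nM; 10000 nM (2 entries), yet compound 4, at 2540 nM, does not reach the numbers of compound 1, so a ring alone does not match butan-2-yl here. The repeats of compound 1 give a sense of how closely runs agree: the several entries of compound 1 in this assay, 600 nM; 450 nM (2 entries)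

The compounds shown leave open how cyclopentyl or phenyl on this nitrogen would read. They also leave open whether a ring holding an oxygen atom, such as tetrahydropyranyl, would differ from cyclohexyl.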